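Ring-carbon methyl removal in a depsipeptide macrocycle series

This account rests on a few compounds, and the source may have more. Where it says the series, first, only, none or still open, it means among the compounds named here.

Two compounds of the series have numbers in a functional assay on A549 cells (Homo sapiens) for antiproliferative activity, read by MTT assay, with a stated time of 72 h; on this read-out higher numbers stand for weaker inhibition and lower numbers for stronger inhibition. Compound 1 `CC[C@H](C)[C@@H]1NC(=O)[C@]2(C)O[C@H]2C[C@@H](OC)/C(C)=C/C=C/[C@@H](C)[C@@H](c2ccccc2)OC(=O)[C@H](C(C)(C)O)NC(=O)[C@@H](Cc2cc(Cl)c(O)c(Cl)c2)NC1=O` gives 557 nM in this assay. Within the data shown here, compound 2 `CC[C@H](C)[C@H]1C(=O)N[C@H](Cc2cc(Cl)c(O)c(Cl)c2)C(=O)N[C@@H](C(C)(C)O)C(=O)O[C@H](c2ccccc2)[C@H](C)/C=C/C=C(\C)[C@H](OC)C[C@@H]2O[C@@]2(C)C(=O)N1C` gives 13.1 nM in this assay, the lowest of the two numbers; the only measured step, a 43-fold lower number from compound 1 to compound 2 (1.63 log units; beyond the scatter), separates it from compound 1.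

Compound 3 `CC[C@H](C)[C@H]1C(=O)N[C@H](Cc2cc(Cl)c(O)c(Cl)c2)C(=O)N[C@@H](C(C)(C)O)C(=O)O[C@H](c2ccccc2)C/C=C/C=C(\C)[C@H](OC)C[C@@H]2O[C@@]2(C)C(=O)N1C` is not yet measured. It differs from compound 2 in one place: hydrogen in place of methyl on a saturated ring carbon.

Among the measured compounds shown here, no measured step bears on this change. For the measured compounds named here, the single step, a 43-fold lower number from compound 1 to compound 2 (1.63 log units; beyond the scatter), concerns a methyl on an amide-type nitrogen in a ring, not a ring carbon, and says nothing about the carbon-bound methyl that leaves here. The change removes one heavy atom from the macrocycle and no donor or acceptor; absent any direct precedent, a step of modest size is expected, with the direction uncertain and a small loss of potency as likely as none.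

For compound 3 the expected number in this assay is 30 nM, with a range from 8 nM to 120 nM. The expected step from compound 2 to compound 3 is a 2.3-fold higher number from compound 2 to compound 3 (0.36 log units; beyond the scatter).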

Compound 3, half-maximal inhibitory concentration: 90.3 nM
Estimate against measurement, compound 3: 3.0-fold (0.48 log units) below, within the range that was stated.
By their numbers in this assay, from the lowest: compound 2; then compound 3; then compound 1.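

Position note, methyl on the saturated ring carbon next to the ring atom that bears a phenyl group: in this assay, this carbon is not indifferent to substitution, since hydrogen in place of its methyl gives a 6.9-fold higher number from compound 2 to compound 3 (0.84 log units; beyond the scatter), a modest step that lies beyond the scatter. The change removes one carbon and no hydrogen-bond donor or acceptor, so potency in this series responds to a methyl on a ring carbon as well as to one on a ring nitrogen, where the earlier step is a 43-fold lower number from compound 1 to compound 2 (1.63 log units; beyond the scatter). Nothing available explains the loss at this position, and the step alone gives no account of how it arises.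

The compounds shown leave open whether an ethyl, a hydroxymethyl or a fluorine on this ring carbon would match the methyl of compound 2 or go beyond it, and whether the opposite configuration of the methyl would hold the same number. They also leave open how the two methyl groups combine in a compound lacking both.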